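Aryl halogen change from compound 3 to compound 4

The source may report more compounds than this note shows. Statements on the series, on what has been measured and on what is new or still open speak of the compounds shown alone.

- compound 1 `Nc1nc(NCCNc2ncc(-c3ncc[nH]3)c(-c3ccccc3Cl)n2)ccc1[N+](=O)[O-]`: > 0.5 h (a limit)
- compound 2 `Nc1nc(NCCNc2ncc(-c3ncc[nH]3)c(-c3cc(F)ccc3F)n2)ccc1[N+](=O)[O-]`: > 0.5 h (a limit)
- compound 3 `Nc1nc(NCCNc2ncc(-c3ncc[nH]3)c(-c3ccc(F)cc3Br)n2)ccc1[N+](=O)[O-]`: > 0.5 h (a limit)

In an ADME assay on microsomes from liver (Canis lupus familiaris) for metabolic stability (on this read-out lower numbers stand for a shorter-lived compound and higher numbers for a longer-lived compound), compound 3 stands at > 0.5 h, which is a limit and not a number. It shares this reading with the other two compounds: the limit of > 0.5 h in this assay, at which 3 of the 3 values shown sit. Compound 4 `Nc1nc(NCCNc2ncc(-c3ncc[nH]3)c(-c3cc(F)c(Cl)cc3Cl)n2)ccc1[N+](=O)[O-]` carries 2,4-dichloro-5-fluorophenyl in place of 2-bromo-4-fluorophenyl on an aromatic carbon. Steps at the same place bear on this change: a step that the two limits leave unreadable from compound 1 to compound 2, and a step that the two limits leave unreadable from compound 1 to compound 3. Like these, a step that the two limits leave unreadable from compound 2 to compound 3 gives no size, so no step beyond the scatter is expected in this assay. The expected step is a step that the limit leaves unreadable from compound 3 to compound 4. For compound 4 the estimated value is 0.7 h, with an expected range of 0.4 h to 1.5 h.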

Compound 4, half-life: > 0.5 h
Compound 4: a limit, no number (the forecaster's own chance of this, stated with the estimate: 75%); the middle value is on the limit's open side.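

Compound 4 reads as a limit in this assay, as do compound 1, compound 2 and compound 3, so no step among these compounds can be read: the limit of > 0.5 h in this assay, at which 4 of the 4 values shown sit.

Still open, on these data alone, is how far each true half-life lies past that limit, and whether the aryl halogen changes shift it at all.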